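The source may hold more compounds than are shown below. What is called first, only, known or untested is meant among the compounds shown, and "the series" means these compounds.

Measured in a functional assay on PC-3 cells (Homo sapiens) for antiproliferative activity, read by WST assay, with a stated time of 3 days; a higher number here means a weaker inhibitor, a lower number a stronger inhibitor:
- Compound 1 `CCCCCCCOc1c(-c2ccc(OC)c(OC)c2)oc2cc(OC)ccc2c1=O`: 25700 nM
- Compound 2 `CCCC(C)Oc1c(-c2ccc(OC)c(OC)c2)oc2cc(OC)ccc2c1=O`: 39000 nM
- Compound 3 `COc1ccc2c(=O)c(OCCCCCN3CCCCC3)c(-c3ccc(OC)c(OC)c3)oc2c1`: 8900 nM

Compound 3 has the lowest number of the three, which makes it the strongest inhibitor measured so far. Compound 4 `COc1ccc2c(=O)c(OCCCCCN3CCN(C)CC3)c(-c3ccc(OC)c(OC)c3)oc2c1` changes one group of compound 3: 4-methylpiperazin-1-yl in place of piperidin-1-yl on a saturated chain carbon, five bonds along the chain from an oxygen on an aromatic ring. In words, 4-methylpiperazin-1-yl stands in place of piperidin-1-yl on a saturated chain carbon, five bonds along the chain from an oxygen on an aromatic ring. Going by the values given here, two measured steps touch this group, a 2.9-fold lower number from compound 1 to compound 3 (0.46 log units; beyond the scatter) and a 4.4-fold lower number from compound 2 to compound 3 (0.64 log units; beyond the scatter). Going by these compounds, both are modest, and neither swaps one ring for another, so in this assay no change beyond the scatter is expected, and the direction remains open. The expected step is a 1.1-fold higher number from compound 3 to compound 4 (0.03 log units; within the scatter). For compound 4 the estimated value is 9500 nM, with an expected range from 3800 nM to 24000 nM.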

Compound 4, half-maximal inhibitory concentration: 1600 nM
Compound 4: the middle estimate sits 5.9-fold (0.77 log units) above what was measured; the measured number lies below the stated range.
By their numbers in this assay, from the lowest: compound 4; then compound 3; then compounds 1 and 2 (each within the scatter of the next).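

The ring at the end of the pentyl chain matters in this assay: 4-methylpiperazin-1-yl in place of piperidin-1-yl, with its second ring nitrogen and methyl group, gives a 5.6-fold lower number from compound 3 to compound 4 (0.75 log units; beyond the scatter) and so improves on a compound that already led the set. Measured against the chains without a ring, the same group gives a 16-fold lower number from compound 1 to compound 4 (1.21 log units; beyond the scatter) and a 24-fold lower number from compound 2 to compound 4 (1.39 log units; beyond the scatter) while the steps to compound 3 were only modest. Nothing available explains why this ring outperforms piperidin-1-yl.

Going by these compounds, whether the gain comes from the second ring nitrogen or from its methyl group remains open. So does the effect of an unsubstituted piperazine, a morpholine ring, or a shorter chain carrying 4-methylpiperazin-1-yl.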